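Moving the chlorine on the urea end of a thiophene-pyrimidine series

The source may report more compounds than this note shows. Statements on the series, on what has been measured and on what is new or still open speak of the compounds shown alone.

Compound 1 `CCN(CC)CCCNc1nc(-c2ccc(NC(=O)Nc3ccc(Cl)cc3)cc2)nc2c(Cl)c(Cl)sc12`: 660 nM
Compound 2 `CCN(CC)CCCNc1nc(-c2ccc(NC(=O)Nc3ccccc3Cl)cc2)nc2c(Cl)c(Cl)sc12`: 970 nM
Compound 3 `CCN(CC)CCNc1nc(-c2ccc(NC(=O)Nc3ccc(Cl)cc3)cc2)nc2ccsc12`: 550 nM

All three were measured in a functional assay on MDA-MB-231 cells (Homo sapiens) for cytotoxicity, read by MTT assay, with a stated time of 72 h; a higher number here means a weaker inhibitor, a lower number a stronger inhibitor. Compound 1 gives 660 nM and compound 2 gives 970 nM; the two differ in one place only, and the step of a 1.5-fold higher number from compound 1 to compound 2 (0.17 log units; within the scatter) is described by 2-chlorophenyl in place of 4-chlorophenyl on an amide-type nitrogen. Compound 3 gives 550 nM; it shares the urea end of compound 1 but differs from it in more than one place, and the difference between the two cores is not broken down here.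

Compound 4 `CCN(CC)CCNc1nc(-c2ccc(NC(=O)Nc3ccccc3Cl)cc2)nc2ccsc12` has not yet been measured in this assay. It stands to compound 3 exactly as compound 2 stands to compound 1: the difference is 2-chlorophenyl in place of 4-chlorophenyl on an amide-type nitrogen, and the place where the group sits is described in the same words for both pairs, so this is the same change made on a second core.

Going by the values given here, the only guide to what it will do is the one earlier step, which stayed within the scatter. The expectation is therefore that compound 4 sits close to compound 3, with a step of about a 1.5-fold higher number from compound 3 to compound 4 (0.16 log units; within the scatter), resting on the step of a 1.5-fold higher number from compound 1 to compound 2 (0.17 log units; within the scatter). On that basis compound 4 is estimated to give 800 nM in this assay, expected to fall between 400 nM and 1600 nM.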

Compound 4, half-maximal inhibitory concentration: 680 nM
Beside the measured number, compound 4's estimate is 1.2-fold (0.07 log units) above it; the range from low to high includes it.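

In this assay, 2-chlorophenyl in place of 4-chlorophenyl on an amide-type nitrogen gives a 1.2-fold higher number from compound 3 to compound 4 (0.09 log units; within the scatter), so on this second core the change again stays inside the normal noise of the measurement. Set beside the earlier step, the two cores give the same answer within what such measurements can resolve: the same change on two cores in this assay, a 1.5-fold higher number (0.17 log units; within the scatter) from compound 1 to compound 2 and a 1.2-fold higher number (0.09 log units; within the scatter) from compound 3 to compound 4, 1.2-fold (0.08 log units) apart, within the scatter of two such steps

This shows that, for these two pairs, the change carried from one core to the other without a step that can be told from scatter, but it does not show that the place of the chlorine is unimportant in general, or that a real effect of the same size exists on both cores, and two small steps on two cores make too narrow a base to predict the result on a third.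

The compounds shown leave open whether a group other than chlorine on the phenyl ring, such as methoxy, trifluoromethyl or nitrile, or a plain phenyl with no chlorine at all, would move the number on either core. They also leave open how much of the difference between the cores comes from the length of the diethylamino chain and how much from the chlorines on the core of compound 1, since the compounds shown never change one of these alone.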